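N-aryl replacement from compound 3 to compound 4

The compounds below may be only part of what the source reports. "The series", "measured", "known", "first", "only" and "open" are said of these compounds alone.

Measured compounds in a functional assay on A549 cells (Homo sapiens) for antiproliferative activity, read by MTT assay, with a stated time of 72 h; a lower number here means a stronger inhibitor, a higher number a weaker inhibitor:
- compound 1 `O=C(Nc1ccc(Oc2ccnc3[nH]ccc23)cc1)c1cc2cccnc2n(-c2ccc(Br)cc2)c1=O`: 280 nM
- compound 2 `O=C(Nc1ccc(Oc2ccnc3[nH]ccc23)cc1)c1cc2cccnc2n(-c2ccc(F)c(Cl)c2)c1=O`: 680 nM
- compound 3 `O=C(Nc1ccc(Oc2ccnc3[nH]ccc23)c(F)c1)c1cc2cccnc2n(-c2ccc(Br)cc2)c1=O`: 210 nM

Compound 3 gives the lowest number of the three in this assay, but its step from compound 1 is within the scatter (a 1.3-fold lower number from compound 1 to compound 3 (0.12 log units; within the scatter)), so the two cannot be ordered; compound 2 sits clearly higher than both, its step from compound 1 being a 2.4-fold higher number from compound 1 to compound 2 (0.39 log units; beyond the scatter).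

Compound 4 `O=C(Nc1ccc(Oc2ccnc3[nH]ccc23)c(F)c1)c1cc2cccnc2n(-c2ccc(C(F)(F)F)cc2Cl)c1=O` is not yet measured. It differs from compound 3 in one place: 2-chloro-4-(trifluoromethyl)phenyl in place of 4-bromophenyl on an aromatic nitrogen. Among the measured compounds shown here, the only measured step that bears on this position is the one from compound 1 to compound 2, also a swap of the aryl group on the aromatic nitrogen, which gave a modest rise in the number. The fluoro step from compound 1 to compound 3 concerns a different place and was within the scatter, so it does not inform this change.

With a single relevant precedent pointing to a modest increase, a step of similar size in the same direction is expected, a 2.1-fold higher number from compound 3 to compound 4 (0.33 log units; beyond the scatter), with wide uncertainty. The number for compound 4 in this assay is estimated at 450 nM, in a range from 180 nM to 1200 nM.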

Compound 4, half-maximal inhibitory concentration: 1020 nM
Compound 4: middle estimate off by 2.3-fold (0.36 log units), on the low side; measured number inside the range.
By their numbers in this assay, from the lowest: compounds 3 and 1 (each within the scatter of the next); then compounds 2 and 4 (each within the scatter of the next).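

In this assay, replacing 4-bromophenyl on the aromatic nitrogen with 2-chloro-4-(trifluoromethyl)phenyl gives a 4.9-fold higher number from compound 3 to compound 4 (0.69 log units; beyond the scatter), so a second, different aryl replacement also raises the number, this time in the fluoro-bearing series. Set beside a 2.4-fold higher number from compound 1 to compound 2 (0.39 log units; beyond the scatter), this means that 4-bromophenyl carries the lower number in both matched pairs, with or without the fluoro on the aromatic carbon, and no compound shown goes against this. No measurement is available that explains the rise from compound 3 to compound 4.

Compound 4 changes the chloro and trifluoromethyl substituents together, so the compounds shown do not separate the share of each, and a phenyl ring bearing only one of them would be needed to do so. Also open, on these data alone, is how this position responds to an unsubstituted phenyl, to a phenyl carrying an amine or a carboxylic acid, or to a plain alkyl chain on the aromatic nitrogen, since every group here is a halogen-bearing phenyl.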